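Aryl substituent swap on the piperazine of the shared core

A few compounds are considered here, and "the series" means these few. Any claim that something is new, unique, unknown or untested is made for them only; others in the source may bear on it.

Measured so far:
compound 1 `COc1ccccc1N1CCN(CCCNc2ncccc2C(=O)N(C)C)CC1` 20 nM
compound 2 `CCCc1ccccc1N1CCN(CCCNc2ncccc2C(=O)N(C)C)CC1` 31.6 nM
compound 3 `CN(C)C(=O)c1cccnc1NCCCN1CCN(c2ccccc2C(F)(F)F)CC1` 316 nM

All three share one core and differ only in the group on the aromatic ring attached to the ring amine nitrogen. In a functional assay on aorta for antagonist activity at Alpha-1D adrenergic receptor (Rattus norvegicus) (on this read-out lower numbers stand for tighter binding and higher numbers for weaker binding), compound 1 gives 20 nM and compound 2 gives 31.6 nM; the step of a 1.6-fold higher number from compound 1 to compound 2 (0.20 log units; within the scatter) is within the scatter. Compound 3 gives 316 nM, the highest number of the three: a 16-fold higher number from compound 1 to compound 3 (1.20 log units; beyond the scatter) and a 10-fold higher number from compound 2 to compound 3 (1.00 log units; beyond the scatter).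

Compound 4 `COc1cc(C)ccc1N1CCN(CCCNc2ncccc2C(=O)N(C)C)CC1` is not yet measured. Its change from compound 3 is 2-methoxy-4-methylphenyl in place of 2-(trifluoromethyl)phenyl on an amine nitrogen in a ring. This largely reverses the step from compound 1 to compound 3, with an added methyl on the entering ring. The step of a 16-fold higher number from compound 1 to compound 3 (1.20 log units; beyond the scatter) bears directly on it, and the step of a 10-fold higher number from compound 2 to compound 3 (1.00 log units; beyond the scatter) points the same way. A drop of that order is therefore expected in this assay, back toward compound 1; nothing here tells what the extra methyl adds. Compound 4 is expected to give about 25 nM, within 10 nM to 70 nM, an estimated step of a 13-fold lower number from compound 3 to compound 4 (1.10 log units; beyond the scatter).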

Compound 4, dissociation constant: 39.8 nM
For compound 4 the middle estimate is 1.6-fold (0.20 log units) below the measured one, and the stated range covers the measured number.
By their numbers in this assay, from the lowest: compounds 1, 2 and 4 (each within the scatter of the next); then compound 3.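

In this assay, the change from 2-(trifluoromethyl)phenyl to 2-methoxy-4-methylphenyl takes the number back to the level of the other compounds (a 7.9-fold lower number from compound 3 to compound 4 (0.90 log units; beyond the scatter)), leaving compound 3 as the only one of the four set apart. The added methyl gives no readable change (a 2.0-fold higher number from compound 1 to compound 4 (0.30 log units; within the scatter)), so in this single pair an aromatic carbon of the methoxyphenyl group takes methyl in place of hydrogen without a shift beyond the scatter. A second group carrying methoxy and methyl also cannot be told from the 2-propylphenyl group (a 1.3-fold higher number from compound 2 to compound 4 (0.10 log units; within the scatter)), so two different substituted phenyl groups stand level here.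

Still open, from the compounds shown here alone, is how an ethoxy, a hydroxyl or a chlorine in place of the methoxy would read, and whether a longer chain in place of the added methyl would shift the number beyond the scatter. No measurement in hand accounts for the gap between the trifluoromethyl compound and the rest.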